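A few compounds are considered here, and "the series" means these few. Any claim that something is new, unique, unknown or untested is made for them only; others in the source may bear on it.

In a functional assay on K562 cells (Homo sapiens) for cytotoxicity, read by MTT assay, with a stated time of 48 h (a lower number here means a stronger inhibitor, a higher number a weaker inhibitor), compound 1 (`Cc1ccccc1CN1CCN(C(=O)CN[C@H]2CCN(S(=O)(=O)Cc3ccccc3)C2)CC1`) gives 10200 nM and compound 2 (`Cc1ccc(CN2CCN(C(=O)CN[C@H]3CCN(S(=O)(=O)Cc4ccccc4)C3)CC2)cc1`) gives 8200 nM. These two numbers lie within the usual scatter of each other, so compound 2 cannot be ranked apart from compound 1. Compound 3 (`O=C(CN[C@H]1CCN(S(=O)(=O)Cc2ccccc2)C1)N1CCN(Cc2ccccc2Cl)CC1`) keeps the same core and changes one group: 2-chlorophenyl in place of 4-methylphenyl on a saturated chain carbon bound to an amine nitrogen in a ring. In words, 2-chlorophenyl stands in place of 4-methylphenyl on a saturated chain carbon bound to an amine nitrogen in a ring. Within the data shown here, only one measured step bears on this change: a 1.2-fold lower number from compound 1 to compound 2 (0.09 log units; within the scatter), which swaps 2-methylphenyl for 4-methylphenyl at that same place. Among the measured compounds shown here, no measured compound carries chlorine, so the data offer no direct guide to that group. With so little to go on, no shift beyond the scatter is expected. The expected change is a 1.0-fold lower number from compound 2 to compound 3 (0.01 log units; within the scatter). For compound 3 the estimated value is 8000 nM, with an expected range of 3500 nM to 16000 nM.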

Compound 3, half-maximal inhibitory concentration: 9000 nM
Compound 3: middle estimate off by 1.1-fold (0.05 log units), on the low side, within the range that was stated.
By their numbers in this assay, from the lowest: compounds 2, 3 and 1 (each within the scatter of the next).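

In this assay, among these compounds, compound 3 is the only one of the three compounds that carries chlorine, and swapping 4-methylphenyl for 2-chlorophenyl stays within the scatter (a 1.1-fold higher number from compound 2 to compound 3 (0.04 log units; within the scatter)). Among the compounds shown here, the cleanest comparison is chloro in place of methyl on an aromatic carbon, which also stays within the scatter (a 1.1-fold lower number from compound 1 to compound 3 (0.05 log units; within the scatter)), so this position so far tolerates methyl or chloro on the aromatic ring with no measurable difference in cytotoxicity. No measurement here explains why these numbers sit so close together.

The compounds shown leave open whether a different kind of group at this place, such as a carboxylic acid or an amine on the aromatic ring, would move the number beyond the scatter. They also leave open what a longer chain in place of the benzyl group would do.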